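Swapping anilino for methylpiperazinyl on the shared core

The source may hold more compounds than are shown below. What is called first, only, known or untested is meant among the compounds shown, and "the series" means these compounds.

compound 1, `N#Cc1c(Nc2ccccc2)nc(SCc2nc3ccccc3[nH]2)nc1-c1ccccc1`: 4.54 nM
compound 2, `CNc1nc(SCc2nc3ccccc3[nH]2)nc(-c2ccccc2)c1C#N`: 3.2 nM
compound 3, `N#Cc1c(-c2ccccc2)nc(SCc2nc3ccccc3[nH]2)nc1N1CCNCC1`: 7.35 nM

All three compounds were tested in a functional assay on NCI-H460 cells (Homo sapiens) for cytotoxicity, read by MTT assay, with a stated time of 3 days; on this read-out lower numbers stand for stronger inhibition and higher numbers for weaker inhibition. Compound 1 stands second highest of the three numbers: its nearest neighbour is compound 2, reached by a 1.4-fold lower number from compound 1 to compound 2 (0.15 log units; within the scatter), and its furthest is compound 3, reached by a 1.6-fold higher number from compound 1 to compound 3 (0.21 log units; within the scatter). Between compound 2 and compound 3 lies a 2.3-fold higher number from compound 2 to compound 3 (0.36 log units; beyond the scatter).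

Compound 4, `CN1CCN(c2nc(SCc3nc4ccccc4[nH]3)nc(-c3ccccc3)c2C#N)CC1`, differs from compound 1 in one place: 4-methylpiperazin-1-yl in place of anilino on an aromatic carbon. Going by the values given here, the step that bears most directly on this is the one from compound 1 to compound 3, where piperazin-1-yl replaced anilino on an aromatic carbon and the number stayed within the scatter. The ring entering compound 4 differs from that of compound 3 only by the methyl in its name, so no more than a small move toward a higher number is expected, estimated as a 1.5-fold higher number from compound 1 to compound 4 (0.19 log units; within the scatter). Compound 4 is therefore expected to give about 7 nM, in a range from 3.5 nM to 14 nM.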

Compound 4, half-maximal inhibitory concentration: 2.84 nM
Compound 4: middle estimate off by 2.5-fold (0.39 log units), on the high side, outside the stated range (below it).
By their numbers in this assay, from the lowest: compounds 4, 2, 1 and 3 (each within the scatter of the next, the first and the last beyond it).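

In this assay, the methyl on the amine nitrogen in the ring matters at this position, with a 2.6-fold lower number from compound 3 to compound 4 (0.41 log units; beyond the scatter) (modest, but beyond the scatter). By contrast, 4-methylpiperazin-1-yl stays within the scatter of both smaller and aromatic neighbours, with a 1.6-fold lower number from compound 1 to compound 4 (0.20 log units; within the scatter) and a 1.1-fold lower number from compound 2 to compound 4 (0.05 log units; within the scatter), so on this aromatic carbon anilino and methylamino can each give way to this non-aromatic ring with no readable change. No measured evidence is available to explain what the methyl does here.

Going by these compounds, whether a longer chain on that ring nitrogen, such as ethyl or 2-hydroxyethyl, or an acetyl group there would behave like the methyl remains open. So does whether morpholin-4-yl, with an oxygen in place of that nitrogen, would fit this position equally well.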